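Trimming one methoxy from a trimethoxyphenyl pyrazole chalcone

This account rests on a few compounds, and the source may have more. Where it says the series, first, only, none or still open, it means among the compounds named here.

Two pyrazole-linked enones sharing the same core have been tested in a functional assay on OVCAR-3 cells (Homo sapiens) for cytotoxicity, read by sulforhodamine B assay, with a stated time of 48 h, tested at 100 uM; a lower number here means a stronger effect, a higher number a weaker effect of the compound at the concentration tested. Compound 1 `COc1cc(-c2cc(/C=C/C(=O)c3ccc(Cl)c(Cl)c3)[nH]n2)cc(OC)c1OC` carries a 3,4-dichlorophenyl on the carbonyl carbon, and in this assay compound 1 gives -30%. Among the compounds with values here, compound 2 `COc1ccc(C(=O)/C=C/c2cc(-c3cc(OC)c(OC)c(OC)c3)n[nH]2)cc1OC` replaces that group with a 3,4-dimethoxyphenyl, and in this assay compound 2 gives -84%, the lowest of the two numbers on record; the only measured step, a number 54 percentage points lower from compound 1 to compound 2 (beyond the scatter), therefore marks compound 2 as the stronger of the pair.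

Compound 3 `COc1ccc(C(=O)/C=C/c2cc(-c3cc(OC)c(OC)c(OC)c3)n[nH]2)cc1` is the next member, differing from compound 2 by hydrogen in place of methoxy on an aromatic carbon, so that 3,4-dimethoxyphenyl becomes 4-methoxyphenyl. Within the data shown here, no measured step speaks directly to removing one methoxy group; the single step from compound 1 to compound 2 concerns the exchange of chlorines for methoxy groups and offers only a loose hint that substitution on this ring matters. The number for compound 3 is therefore estimated at -60%, between -95% and -20%, implying an expected step of a number 24 percentage points higher from compound 2 to compound 3 (beyond the scatter).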

Compound 3, a percentage reported as activity, at one concentration (the size of the read-out at that concentration, not a potency): -69%
For compound 3 the middle estimate is 9 percentage points above the measured one; the range from low to high includes it.
By their numbers in this assay, from the lowest: compound 2; then compound 3; then compound 1.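

The change shows that the methoxy group ortho to a methoxy group counts for something on its own: in this assay, trimming 3,4-dimethoxyphenyl to 4-methoxyphenyl gives a number 15 percentage points higher from compound 2 to compound 3 (beyond the scatter), a modest step and the first one that touches this group alone. The single methoxy that remains still keeps the compound well ahead of the dichloro analogue, with a number 39 percentage points lower from compound 1 to compound 3 (beyond the scatter), a large step, so the exchange of 3,4-dichlorophenyl for 4-methoxyphenyl already carries much of the gain, and the added methoxy of compound 2 supplies a smaller further part. Nothing available explains why either step takes the size it does.

The compounds shown leave open whether the remaining methoxy matters as well, which an unsubstituted phenyl on the carbonyl carbon would address, and whether a hydroxy group, an amine or a longer chain such as ethoxy could stand in for the methoxy that left. They also leave open whether the trimethoxyphenyl on the other side of the shared core tolerates the same trimming, since all three compounds keep it unchanged.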